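The source may hold more compounds than are shown below. What is called first, only, known or untested is meant among the compounds shown, and "the series" means these compounds.

Of the compounds shown here, two sharing one core have been measured in a functional assay on Raji cells (Homo sapiens) for inhibition, read by MTT assay, with a stated time of 96 h; on this read-out lower numbers stand for an effect already at smaller amounts and higher numbers for an effect only at larger amounts of compound. Compound 1, with the structure `CC(C)Cn1c(=O)n(C)c(=O)c2[nH]c(=O)c(Cc3cccc4ccccc34)nc21`, gives only a limit of the assay there: in this assay compound 1 reaches > 10000 nM. Among the measured compounds shown here, compound 2, with the structure `CC(C)Cn1c(=O)n(C)c(=O)c2nc([S+]([O-])CCCO)c(Cc3cccc4ccccc34)nc21`, is the one compound with a measured number, and in this assay compound 2 gives 1990 nM. Compound 2 therefore stands as the only number shown, while the other value shown is a limit (the limit of > 10000 nM in this assay, at which 1 of the 2 values shown sits), so no measured step between two numbers is available to set a scale.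

Compound 3, with the structure `CC(C)Cn1c(=O)n(C)c(=O)c2nc(C(=O)N(C)CCCO)c(Cc3cccc4ccccc34)nc21`, differs from compound 2 in one place: a group of 8 heavy atoms (5 carbon, 1 nitrogen, 2 oxygen; no ring) in place of a group of 6 heavy atoms (3 carbon, 2 oxygen, 1 sulfur; no ring), on an aromatic carbon. In words, a group of 8 heavy atoms (5 carbon, 1 nitrogen, 2 oxygen; no ring) replaces a group of 6 heavy atoms (3 carbon, 2 oxygen, 1 sulfur; no ring) on an aromatic carbon, next to the ring nitrogen and ortho to the (naphthalen-1-yl)methyl group. For the measured compounds named here, with no measured step to lean on, the step is expected to be small, near the scatter, with a slight lean toward weaker activity, as a 1.4-fold higher number from compound 2 to compound 3 (0.15 log units; within the scatter). Compound 3 is estimated at 2800 nM, within 900 nM to 9000 nM.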

Compound 3, half-maximal effective concentration: > 10000 nM
Compound 3 was reported as a limit (the forecaster's own chance of this, stated with the estimate: 20%); middle value at least 3.5-fold (0.55 log units) from the limit.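

In this assay, replacing the sulfur-bearing group on this aromatic carbon with the (3-hydroxypropyl)(methyl)carbamoyl group gives an at least 5.0-fold higher number from compound 2 to compound 3 (0.70 log units; beyond the scatter), so the read-out at this position responds to the change even though the two groups match in the hydrogen-bond donors and acceptors counted for them. Compound 3 gives > 10000 nM, which is a limit of the assay and not a number, so the printed size of the step marks only its smallest possible extent. Compound 2 thus remains the only compound shown with a measured number, and the other two compounds stop at the same limit: the limit of > 10000 nM in this assay, at which 2 of the 3 values shown sit.

Among the compounds shown here, the single pair does not separate the part played by the atom joined to the ring from that of the rest of the chain, and it does not show how far the true value of compound 3 lies from the limit. Also open, from the compounds shown here alone, is whether a thioether, an amine, a carboxylic acid or a longer chain on this aromatic carbon would give a measured number in this assay, and how such a number would compare with that of compound 2.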